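Removing the methyl from a bis-trifluoromethyl urea

The source may report more compounds than this note shows. Statements on the series, on what has been measured and on what is new or still open speak of the compounds shown alone.

Compound 1 `O=C(Nc1cccc(-n2cc(-c3ccncc3)c(-c3ccc(Cl)c(O)c3)n2)c1)Nc1cccc(C(F)(F)F)c1` gives > 32500 nM in a functional assay on M14 cells (Homo sapiens) for inhibition, read by sulforhodamine B assay, with a stated time of 48 h (a lower number here means that less compound is tolerated, a higher number that more compound is tolerated), a limit of the assay.
Compound 2 `COc1cc(-c2nn(-c3cccc(NC(=O)Nc4cc(C(F)(F)F)cc(C(F)(F)F)c4)c3)cc2-c2ccncc2)ccc1Cl` gives > 50000 nM in this assay, again a limit.
Compound 3 `COc1cc(-c2nn(-c3cccc(NC(=O)Nc4cccc(C(F)(F)F)c4)c3)cc2-c2ccncc2)ccc1Cl` gives 4650 nM in this assay.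

Compound 2 stands at the top of what is known here: its value is a limit, and the number sits at the limit of > 50000 nM in this assay, at which 1 of the 3 values shown sits, rather than at a measured point. Compound 4 `O=C(Nc1cccc(-n2cc(-c3ccncc3)c(-c3ccc(Cl)c(O)c3)n2)c1)Nc1cc(C(F)(F)F)cc(C(F)(F)F)c1` differs from compound 2 in one place, (hydrogen in place of methyl on an oxygen on an aromatic ring); the same difference, cut one bond further out, reads methoxy to hydroxy.

Within the data shown here, two measured steps bear on this. The step of an at least 6.9-fold lower number from compound 1 to compound 3 (0.84 log units; beyond the scatter) is the same exchange run the other way, methyl entering for hydrogen, and it lowered the number. The step of an at least 10-fold lower number from compound 2 to compound 3 (1.03 log units; beyond the scatter) shows that taking away one trifluoromethyl from compound 2 also lowered the number. Compound 4 keeps both trifluoromethyl groups and loses the methyl, so nothing here points to a lower number; the expectation is a value at or above the limit, with the step that the limit leaves unreadable from compound 2 to compound 4 expected to run in the direction of more compound tolerated. For compound 4 the estimate in this assay is 100000 nM, expected to lie between 40000 nM and 400000 nM, most likely reported again as a limit.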

Compound 4, concentration lethal to 50% of the cells: 6060 nM
Estimate against measurement, compound 4: 17-fold (1.22 log units) above, and the stated range ends above it.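

Methoxy to hydroxy does not leave the number high on the urea with two trifluoromethyl groups: in this assay the step is an at least 8.2-fold lower number from compound 2 to compound 4 (0.91 log units; beyond the scatter), so the methyl on this oxygen is not neutral there. Its effect depends on the rest of the molecule, since methyl in place of hydrogen lowers the number when one trifluoromethyl is present and raises it when two are present: the same change on two cores in this assay, an at least 6.9-fold lower number (0.84 log units; beyond the scatter) from compound 1 to compound 3 and an at least 8.2-fold higher number (0.91 log units; beyond the scatter) from compound 4 to compound 2, at least 57-fold (1.76 log units) apart, beyond the scatter of two such steps. The second trifluoromethyl, on the hydroxy compounds, gives an at least 5.3-fold lower number from compound 1 to compound 4 (0.72 log units; beyond the scatter), which reverses the direction seen on the methoxy pair and shows that the two places do not act independently: the same change on two cores in this assay, an at least 10-fold lower number (1.03 log units; beyond the scatter) from compound 2 to compound 3 and an at least 5.3-fold higher number (0.72 log units; beyond the scatter) from compound 4 to compound 1, at least 57-fold (1.76 log units) apart, beyond the scatter of two such steps.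

Going by these compounds, compound 1 and compound 2 each stand only at a limit of the assay, so the full size of these steps and of the gap between them remains open. Also open, on these data alone, is whether an ethyl chain on the same oxygen, or an amine in place of the hydroxy, would follow the methyl or the hydrogen on either urea.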